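Uncapping the Alkyne: An Expected Gain for Compound 4

The source may hold more compounds than are shown below. What is called first, only, known or untested is meant among the compounds shown, and "the series" means these compounds.

Measured compounds:
Compound 1, `C[Si](C)(C)C#Cc1cc(-c2nc3ccc(F)cc3s2)ccc1N`: 680 nM
Compound 2, `C#Cc1cc(-c2nc3c(F)cccc3s2)ccc1N`: 110 nM
Compound 3, `C[Si](C)(C)C#Cc1cc(-c2nc3c(F)cccc3s2)ccc1N`: 520 nM

In a functional assay on MCF7 cells (Homo sapiens) for inhibition, with a stated time of 72 h (a higher number here means a weaker inhibitor of growth, a lower number a stronger inhibitor of growth), compound 1 gives 680 nM, compound 2 gives 110 nM and compound 3 gives 520 nM. Compound 1 and compound 3 have the same atoms joined differently; the difference between their two cores is not broken down here, and their values lie within the usual scatter of each other. Within the data shown here, the one step that is measured, a 4.7-fold lower number from compound 3 to compound 2 (0.67 log units; beyond the scatter), comes from the change (a hydrogen atom in place of a group of 4 heavy atoms (3 carbon, 1 silicon; no ring), on a triple-bonded carbon).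

Compound 4, `C#Cc1cc(-c2nc3ccc(F)cc3s2)ccc1N`, has not yet been measured in this assay. It differs from compound 1 by a hydrogen atom in place of a group of 4 heavy atoms (3 carbon, 1 silicon; no ring), on a triple-bonded carbon, the same kind of change as that from compound 3 to compound 2, and made at a place described in the same words. On the strength of a 4.7-fold lower number from compound 3 to compound 2 (0.67 log units; beyond the scatter), compound 4 is expected to show a step of a 4.5-fold lower number from compound 1 to compound 4 (0.66 log units; beyond the scatter) from compound 1, because compound 1 starts from 680 nM. Compound 4 is therefore estimated at 150 nM, with a likely range from 70 nM to 350 nM.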

Compound 4, concentration for 50% growth inhibition: 110 nM
For compound 4 the middle estimate is 1.4-fold (0.13 log units) above the measured one, and the stated range covers the measured number.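

In this assay, putting a hydrogen atom in place of the group of 4 heavy atoms (3 carbon, 1 silicon) on the triple-bonded carbon gives a 6.2-fold lower number from compound 1 to compound 4 (0.79 log units; beyond the scatter). Set beside the earlier step, the change carries from one core to the other with no difference in size that can be told apart: the same change on two cores in this assay, a 4.7-fold lower number (0.67 log units; beyond the scatter) from compound 3 to compound 2 and a 6.2-fold lower number (0.79 log units; beyond the scatter) from compound 1 to compound 4, 1.3-fold (0.12 log units) apart, within the scatter of two such steps This shows that the step held on the two cores seen here, which have the same atoms joined differently, but it does not show that it would hold on a core further removed from these, and it gives no reason why the number falls.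

The compounds shown leave open whether a methyl group, a longer alkyl chain or a phenyl ring on the triple-bonded carbon would give a number as low as the hydrogen atom does. They also do not tell whether the step would keep its size on a core carrying chlorine in place of the fluorine.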